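The source may hold more compounds than are shown below. What is called first, only, known or untested is meant among the compounds shown, and "the series" means these compounds.

Measured compounds: compound 1 `CCCCCCCCCCCCCCCCOP(=O)(O)OCCSC(=S)N1CCCCC1`, compound 2 `CCCCCCOP(=O)(O)OCCSC(=S)N1CCCCCC1`, compound 3 `CCCCCCOP(=O)(O)OCCSC(=S)N1CCCC1`.

In a functional assay on MCF7 cells (Homo sapiens) for inhibition, read by MTT assay, with stated times of 18 h and 4 h (a lower number here means a stronger inhibitor, a higher number a weaker inhibitor), compound 1 gives 29000 nM, the lowest of the three numbers. Among the measured compounds shown here, compound 2 gives 55000 nM, and compound 3 gives 100000 nM; the one step measured between them, a 1.8-fold higher number from compound 2 to compound 3 (0.26 log units; within the scatter), concerns the ring only. Compound 4 `CCCCCCCCOP(=O)(O)OCCSC(=S)N1CCCCC1` differs from compound 1 by hydrogen in place of octyl on a saturated chain carbon, eight bonds along the chain from an oxygen on an unsaturated carbon. For the measured compounds named here, no measured step covers a change of chain length, so the only guide is that the two hexyl compounds, compound 2 and compound 3, sit at higher numbers than compound 1 while also differing in the ring. The expectation for compound 4 is therefore a modest rise, a 2.1-fold higher number from compound 1 to compound 4 (0.32 log units; beyond the scatter), with wide uncertainty. Compound 4 is estimated at 60000 nM, in the range 25000 nM to 150000 nM.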

Compound 4, half-maximal inhibitory concentration: 26000 nM
Compound 4: middle estimate off by 2.3-fold (0.36 log units), on the high side; the range from low to high includes it.
By their numbers in this assay, from the lowest: compounds 4, 1, 2 and 3 (each within the scatter of the next, the first and the last beyond it).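

In this assay, hydrogen in place of octyl on a saturated chain carbon, eight bonds along the chain from an oxygen on an unsaturated carbon, gives a 1.1-fold lower number from compound 1 to compound 4 (0.05 log units; within the scatter). This single chain step shows that the octyl portion at this place can go without moving the number beyond the scatter, with the ring of compound 1 held fixed. No supporting data bear on why the two chain lengths read alike.

Open, as far as these compounds go, is whether a butyl chain, or an amine or carboxylic acid at the chain end, would separate from compound 4. Also open, from the compounds shown here alone, is how a chain change reads on the pyrrolidin-1-yl or azepan-1-yl compounds.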